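From a Charged Aryl Group to Dimethylamino

The source may report more compounds than this note shows. Statements on the series, on what has been measured and on what is new or still open speak of the compounds shown alone.

Compound 1 `COC(=O)C1=C(C)N=C(C)/C(=C(\O)OC)C1c1cccc([N+](C)(C)C)c1`: 50100 nM
Compound 2 `COC(=O)C1=C(C)N=C(C)/C(=C(\O)OC)C1c1ccccc1N`: 39800 nM
Compound 3 `COC(=O)C1=C(C)N=C(C)/C(=C(\O)OC)C1c1ccccc1C`: 6.03 nM

In a functional assay (muscle tissue) with Cavia porcellus as the target (on this read-out lower numbers stand for an effect already at smaller amounts and higher numbers for an effect only at larger amounts of compound), compound 1 and compound 2 give numbers that lie within the scatter of each other, and both sit far above compound 3. Going by the values given here, the one single-place step measured, a 6600-fold lower number from compound 2 to compound 3 (3.82 log units; beyond the scatter), involves a different exchange at a different place on the ring, so it does not bear directly on the move to compound 4 `COC(=O)C1=C(C)N=C(C)/C(=C(\O)OC)C1c1cccc(N(C)C)c1`, where (a group of 3 heavy atoms (2 carbon, 1 nitrogen; no ring) in place of a group of 4 heavy atoms (3 carbon, 1 nitrogen; no ring), on an aromatic carbon). It only shows that one change on this ring can shift the read-out greatly. Lacking a direct comparison, compound 4 is estimated at 5000 nM, with a wide range from 300 nM to 50000 nM. The expected step is a 10-fold lower number from compound 1 to compound 4 (1.00 log units; beyond the scatter).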

Compound 4, half-maximal effective concentration: 891 nM
For compound 4 the middle estimate is 5.6-fold (0.75 log units) above the measured one; the measured number falls inside the stated range.
By their numbers in this assay, from the lowest: compound 3; then compound 4; then compounds 2 and 1 (each within the scatter of the next).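

Going by these compounds alone, compounds 1 and 4 differ in one place only, so this is the first direct reading of the group on this aromatic carbon. In this assay, replacing the group with a net charge of +1 by dimethylamino, which has no net charge, gives a 56-fold lower number from compound 1 to compound 4 (1.75 log units; beyond the scatter) and shows that this place alone can change the read-out beyond the scatter. No measurement here gives a reason for this step.

Going by these compounds, whether an uncharged group of similar size, such as isopropyl, would give a similar number remains open, and so does the effect of a simple amino group or diethylamino at this place.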